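The source may report more compounds than this note shows. Statements on the series, on what has been measured and on what is new or still open speak of the compounds shown alone.

Measured in a functional assay on the whole organism (strain albino) for inhibition, with Rattus norvegicus as the target, read by paw edema, with a stated time of 1 h, at a dose of 100 mg/kg by the oral route; on this read-out higher numbers stand for more inhibition at the one dose given (going by the name of the read-out) and lower numbers for less inhibition:

compound 1, `N#Cc1c(-c2ccccc2)nc(SCC(=O)Nn2c(COc3ccc(Cl)cc3Cl)nc3ccccc3c2=O)n(Cc2ccccc2)c1=O`: 77.3%
compound 2, `N#Cc1c(-c2ccc(Cl)cc2)nc(SCC(=O)Nn2c(COc3ccc(Cl)cc3Cl)nc3ccccc3c2=O)n(Cc2ccccc2)c1=O`: 72.7%
compound 3, `N#Cc1c(Cl)nc(SCC(=O)Nn2c(COc3ccc(Cl)cc3Cl)nc3ccccc3c2=O)nc1-c1ccccc1`: 60%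

Compound 1 and compound 2 share one core; compound 2 carries chloro in place of hydrogen on an aromatic carbon. That change gave a number 4.6 percentage points lower from compound 1 to compound 2 (within the scatter), so on this read-out the two are indistinguishable. Compound 3 is built on a different core; how the two cores differ is not broken down here, and compound 3 simply reads lower than both of the others.

Compound 4, `N#Cc1c(Cl)nc(SCC(=O)Nn2c(COc3ccc(Cl)cc3Cl)nc3ccccc3c2=O)nc1-c1ccc(Cl)cc1`, has not yet been measured. It differs from compound 3 by chloro in place of hydrogen on an aromatic carbon, the same change seen between compound 1 and compound 2, at the same kind of place. Because a number 4.6 percentage points lower from compound 1 to compound 2 (within the scatter) was small, a step of about a number 4 percentage points lower from compound 3 to compound 4 (within the scatter) is expected from compound 3 to compound 4. Compound 4 is therefore estimated at 56%, most likely between 45% and 67%.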

Compound 4, a percentage reported as inhibition, in the whole organism at one dose (the size of the read-out at that dose, not a potency): 63.6%
Compound 4: middle estimate off by 7.6 percentage points, on the low side, within the range that was stated.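

In this assay, the change from phenyl to 4-chlorophenyl gave a number 3.6 percentage points higher from compound 3 to compound 4 (within the scatter), so compound 3 and compound 4 cannot be told apart on this read-out. Set beside the same change on the core of compound 1, the two steps agree: the same change on two cores in this assay, a number 4.6 percentage points lower (within the scatter) from compound 1 to compound 2 and a number 3.6 percentage points higher (within the scatter) from compound 3 to compound 4, 8.2 percentage points apart, within the scatter of two such steps. In these two pairs, then, the change carried from one core to the other without a readable effect, but this does not show which way it acts, if it acts at all, or that it would behave the same on any other core.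

The compounds shown leave open how a fluoro, a methoxy or an amine would read at this place on the ring. They also leave open whether a carboxylic acid there would move the read-out beyond the scatter.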